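The compounds below may be only part of what the source reports. "The series", "measured", "known", "first", "only" and "open" are said of these compounds alone.

Measured compounds:
Compound 1 `COC(=O)c1ccc(NCc2cncn2Cc2ccccc2N)cc1-c1ccccc1` — 25000 nM
Compound 2 `COC(=O)c1ccc(NCc2cncn2Cc2ccc(C(C)(C)C)cc2)cc1-c1ccccc1` — "not determined" (no result reported)
Compound 3 `COC(=O)c1ccc(NCc2cncn2Cc2ccc(OC)cc2)cc1-c1ccccc1` — "not determined" (no result reported)

In a toxicity assay on NIH3T3 cells (Mus musculus) for cytotoxicity, read by resazurin assay (on this read-out higher numbers stand for an effect only at larger amounts of compound and lower numbers for an effect already at smaller amounts), compound 1 gives 25000 nM. Compound 2 gives no number in this assay, and compound 3 gives none either, so compound 3 stands without a value among the measured compounds, and only compound 1 offers a number to lean on. Compound 4 `COC(=O)c1ccc(NCc2cncn2Cc2ccccc2C#N)cc1-c1ccccc1` shares the core of compound 3 and differs from it by 2-cyanophenyl in place of 4-methoxyphenyl on a saturated chain carbon bound to an aromatic nitrogen. Within the data shown here, no step between measured compounds in this assay is known, so the size and direction of the change from compound 3 to compound 4 cannot be read from the data; a shift no larger than the usual scatter is expected. For compound 4 in this assay a value near 25000 nM is estimated, in the range 8000 nM to 80000 nM.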

Compound 4, half-maximal effective concentration: 25000 nM
The estimate for compound 4 equals the measured number at the digits printed; the measured number falls inside the stated range.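

In this assay, among these compounds, there is now a first pair of compounds that differ in one place: no change at the digits printed from compound 1 to compound 4 (within the scatter), with cyano in place of amino on an aromatic carbon. At this place, then, the swap leaves the read-out unmoved, though this is a single pair. No measurement at hand offers an explanation for this result. Steps to compound 2 and compound 3 cannot be read, since neither has a number. On these data alone, whether a carboxylic acid or a dimethylamino group at this place would also leave the read-out unmoved remains open.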